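The source may report more compounds than this note shows. Statements on the series, on what has been measured and on what is new or still open speak of the compounds shown alone.

Working notes on the 2-hydroxyacid oxidase series.

Three compounds have numbers in an assay on isolated protein (Sus scrofa) for inhibition of 2-Hydroxyacid oxidase 1 (Homo sapiens) (on this read-out higher numbers stand for weaker inhibition and lower numbers for stronger inhibition), so far. Compound 1 `O=C(/C=C/c1ccccc1)CC(=O)C(=O)O` gives 19000 nM in this assay. Compound 2 `CCCCCCCCCc1ccc(C(=O)CC(=O)C(=O)O)cc1` gives 600 nM in this assay. Compound 3 `O=C(O)C(=O)CC(=O)c1ccc(-c2ccc(Br)cc2)cc1` gives 63 nM in this assay, the lowest of the three numbers; the gap to compound 2 and the larger gap to compound 1 both lie beyond the usual scatter. Across these three, the shared core of compound 1 carries progressively larger aryl substitution, and the number falls along that line, though no single-change step between any two of them exists to be quoted.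

Compound 4 `O=C(O)C(=O)CC(=O)c1ccc(-c2ccc(SCCc3ccncc3)cc2)cc1` has not yet been measured in this assay. The change from compound 3 is (2-(pyridin-4-yl)ethyl)sulfanyl in place of bromo on an aromatic carbon, sitting on an aromatic carbon of a six-membered aromatic ring of carbon only, para to a large group. Within the data shown here, no measured pair in the set tracks this kind of exchange, so the expectation rests on the position of compound 3 alone. The number for compound 4 is expected to stay near that of compound 3, with any step a 1.4-fold lower number from compound 3 to compound 4 (0.15 log units; within the scatter) expected to be small and not clearly beyond the scatter. Compound 4 is therefore estimated at 45 nM in this assay, within a range of 10 nM to 200 nM.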

Compound 4, half-maximal inhibitory concentration: 90 nM
The estimate for compound 4 lay 2.0-fold (0.30 log units) below the measured number; measured number inside the range.
By their numbers in this assay, from the lowest: compounds 3 and 4 (each within the scatter of the next); then compound 2; then compound 1.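

In this assay, among these compounds, the exchange of bromo for (2-(pyridin-4-yl)ethyl)sulfanyl on an aromatic carbon, para to a large group, gives a 1.4-fold higher number from compound 3 to compound 4 (0.15 log units; within the scatter), and this is the first step that changes one place only. Among the compounds shown here, it shows that this position can carry the entering group, with 9 heavy atoms and a six-membered aromatic ring with 1 hetero atom, in place of a single bromine while the two compounds remain within the scatter of each other, something the earlier compounds, which differ in more than one place, could not show. No supporting data are available to explain this result.

The compounds shown leave open which part of the entering group matters, as they do not separate the sulfur, the ethyl chain and the pyridine ring; an ether oxygen in place of the sulfur, a longer chain in place of the ethyl, or a phenyl ring in place of the pyridine would each address one part. Also open, from the compounds shown here alone, is how this position responds to a charged group, such as an amine or a carboxylic acid, at the end of the substituent.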